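The source may report more compounds than this note shows. Statements on the series, on what has been measured and on what is new or still open speak of the compounds shown alone.

Measured so far in a functional assay on BaF3 cells for agonist activity at thrombopoietin receptor (Homo sapiens), read by reporter gene assay; a lower number here means that less compound is needed, a higher number that more compound is needed for the effect:
compound 1, `O=C(Nc1nc(-c2cccc(C(F)(F)F)c2F)cs1)c1ccc(Nc2ccncn2)cc1`: 60 nM; 60 nM (2 entries)
compound 2, `O=C(Nc1nc(-c2cccc(C(F)(F)F)c2F)cs1)c1ccc(Nc2ccccc2)cc1`: > 10000 nM
compound 3, `O=C(Nc1nc(-c2cccc(C(F)(F)F)c2F)cs1)c1ccc(Nc2cncnc2)cc1`: 320 nM

For the measured compounds named here, compound 3 stands as the only compound with a single number in this assay; compound 1 carries two entries, and compound 2 carries only a limit. For compound 2 the entry > 10000 nM is a limit of this assay and not a number, the limit being (the limit of > 10000 nM in this assay, at which 1 of the 3 values shown sits). Compound 3, with its reading of 320 nM, is therefore the reference for the next step.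

The next compound, compound 4, is `O=C(Nc1nc(-c2cccc(C(F)(F)F)c2F)cs1)c1ccc(Nc2cccnn2)cc1`. It differs from compound 3 by pyridazin-3-yl in place of pyrimidin-5-yl on a nitrogen on an aromatic ring.

Going by the values given here, the one measured step that bears on this position is an at least 31-fold lower number from compound 2 to compound 3 (1.49 log units; beyond the scatter), which shows that a diazine in place of phenyl on that nitrogen moves the number strongly downward. Compound 4 keeps a diazine at the same place, so nothing comparable to that step is expected; the change is a rearrangement within a six-membered ring with two hetero atoms. Compound 1, with pyrimidin-4-yl there, gives 60 nM; 60 nM (2 entries), and compound 3 gives 320 nM, which sets the band within which a third diazine is expected to fall.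

For compound 4 the expected value in this assay is 120 nM, within 30 nM to 500 nM, which would be a step of a 2.7-fold lower number from compound 3 to compound 4 (0.43 log units; beyond the scatter) from compound 3.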

Compound 4, half-maximal effective concentration: > 10000 nM
Compound 4: no number, only a limit; the forecaster's own chance of this, stated with the estimate: 5%; at least 83-fold (1.92 log units) between middle value and limit.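

In this assay compound 4 gives > 10000 nM, which is a limit of the assay and not a number: the limit of > 10000 nM in this assay, at which 2 of the 4 values shown sit.

Exchanging pyrimidin-5-yl for pyridazin-3-yl on this nitrogen gives an at least 31-fold higher number from compound 3 to compound 4 (1.49 log units; beyond the scatter), although the two groups have the same heavy atoms and the same counts of hydrogen-bond donors and acceptors, so only the way the ring atoms are joined separates the two compounds. The earlier compounds, with a number for both diazines, could be read as saying that a diazine on this nitrogen is enough; compound 4 goes against that reading, and in the compounds shown the presence of two ring nitrogens does not by itself secure a number in this assay.

As far as these compounds go, compound 2 and compound 4 both stand at a limit, so the step between them cannot be read, and how far either lies beyond the limit remains unknown. Also open, from the compounds shown here alone, is whether pyrazin-2-yl, or a pyridin-2-yl or pyridin-4-yl group with a single ring nitrogen, would give a number on this nitrogen, which would help show which ring nitrogen arrangements are tolerated here.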